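The source may hold more compounds than are shown below. What is called first, only, known or untested is meant among the compounds shown, and "the series" means these compounds.

Compound 1 `COc1ccc(Cn2c(-c3ccccc3)c(-c3ccccc3)c3c(=N)n(CCO)cnc32)cc1` gives > 1000 10^-6 cm/s in an ADME assay for permeability, using PAMPA, with a stated time of 30 min, at pH 7.4; on this read-out lower numbers stand for lower permeability and higher numbers for higher permeability.
Compound 2 `OCCCNc1ncnc2c1c(-c1ccccc1)c(-c1ccccc1)n2Cc1ccccc1` gives "nd" (no result reported) in this assay.
Compound 3 `N=c1c2c(-c3ccccc3)cn(Cc3ccccc3)c2ncn1C1CCOCC1` gives 1730 10^-6 cm/s in this assay.

The value of compound 1 in this assay is a limit of the assay, not a number, and it is the limit of > 1000 10^-6 cm/s in this assay, at which 1 of the 3 values shown sits. Compound 2 gave no result, so compound 3 supplies the only single number among these compounds. Compound 4 `COc1ccc(Cn2c(-c3ccccc3)c(-c3ccccc3)c3c(=N)n(CC4CCOCC4)cnc32)cc1` differs from compound 1 by oxan-4-yl in place of hydroxymethyl on a saturated chain carbon bound to an aromatic nitrogen. Among the measured compounds shown here, no step between measured compounds is available to guide this change. Compound 4 is expected to stay in the region where compound 1 already stands, so the step that the limit leaves unreadable from compound 1 to compound 4 is expected to be none beyond the scatter, or slightly upward. Compound 4 is therefore estimated at 1500 10^-6 cm/s, within 800 10^-6 cm/s to 3000 10^-6 cm/s, and a limit rather than a number may again be reported.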

Compound 4, apparent permeability: 1270 10^-6 cm/s
For compound 4 the middle estimate is 1.2-fold (0.07 log units) above the measured one; low and high end bracket the measured number.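

Among the compounds shown here, compound 1 stands at a limit of the assay, so no step from it to compound 4 can be read: the limit of > 1000 10^-6 cm/s in this assay, at which 1 of the 4 values shown sits. The compounds shown leave open how much apparent permeability changes with oxan-4-yl in place of hydroxymethyl, or whether it changes at all.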